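From Isobutyl to 4-Methoxyphenyl on the Shared Core

The source may hold more compounds than are shown below. What is called first, only, known or untested is meant among the compounds shown, and "the series" means these compounds.

Compound 1 `CC(C)Cc1ccc2c(NCCCNCc3ccco3)ccnc2c1`: 16000 nM
Compound 2 `COc1cccc(CNCCCNc2ccnc3cc(-c4ccc(C(C)(C)C)cc4)ccc23)c1O`: 690 nM

In an ADME assay on HepG2 cells (Homo sapiens) for cytotoxicity, read by luminescence, CellTiter-Glo and ATP content, with a stated time of 72 h (a lower number here means that less compound is needed, a higher number that more compound is needed for the effect), compound 1 gives 16000 nM, the highest of the two numbers recorded. Compound 2 gives 690 nM in this assay, a lower number, and the gap between the two lies beyond the scatter. Going by the values given here, no step between compounds differing in a single place is available, so the two values are all that can be compared.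

Compound 3 `COc1ccc(-c2ccc3c(NCCCNCc4ccco4)ccnc3c2)cc1` has not been measured in this assay. It differs from compound 1 in one place: 4-methoxyphenyl in place of isobutyl on an aromatic carbon.

Because compound 2 gives 690 nM with a larger group on the shared core, a step downward from compound 1 to compound 3 is expected, of a size beyond the scatter: a 4.6-fold lower number from compound 1 to compound 3 (0.66 log units; beyond the scatter). For compound 3 the estimate in this assay is 3500 nM, with a range from 1000 nM to 12000 nM.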

Compound 3, half-maximal effective concentration: 6000 nM
The estimate for compound 3 lay 1.7-fold (0.23 log units) below the measured number; the measured number falls inside the stated range.
By their numbers in this assay, from the lowest: compound 2; then compound 3; then compound 1.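

In this assay, the aromatic carbon of the shared core proves to be a position where a single change moves the number: with the rest of the molecule unchanged, 4-methoxyphenyl in place of isobutyl gives a 2.7-fold lower number from compound 1 to compound 3 (0.43 log units; beyond the scatter), a modest step. Going by these compounds alone, the earlier pair differed in more than one place, so this is the first effect that can be tied to this position alone. The change brings in a six-membered aromatic ring of carbon only and a hydrogen-bond acceptor, but no measurement at hand bears on what lies behind the step.

The compounds shown leave open whether the step belongs to the ring itself or to its methoxy group, and where an unsubstituted phenyl would stand. Also open, as far as these compounds go, is how an amine or a longer alkyl chain on this carbon would compare.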